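A few compounds are considered here, and "the series" means these few. Any claim that something is new, unique, unknown or untested is made for them only; others in the source may bear on it.

In a functional assay on MGC-803 cells (Homo sapiens) for inhibition, read by MTT assay, with a stated time of 48 h (a lower number here means a stronger inhibitor, a higher number a weaker inhibitor), compound 1 `COc1ccc(-c2coc3cc(OCCCBr)ccc3c2=O)cc1` gives 64900 nM. Compound 2 `COc1ccc(-c2coc3cc(OCCCCCBr)ccc3c2=O)cc1` reads > 100000 nM, which is a limit of the assay and not a number. Compound 2 therefore offers no exact starting point for the next step.

The change to compound 3 `COc1ccc(-c2coc3cc(OCCCSC(=S)N4CCOCC4)ccc3c2=O)cc1` is a group of 9 heavy atoms (5 carbon, 1 nitrogen, 1 oxygen, 2 sulfur; one six-membered non-aromatic ring with 2 hetero atoms) in place of a group of 3 heavy atoms (2 carbon, 1 bromine; no ring), on a saturated chain carbon, three bonds along the chain from an oxygen on an aromatic ring. The new group has a six-membered non-aromatic ring with 2 hetero atoms and replaces 2-bromoethyl on the same chain carbon.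

Among the measured compounds shown here, the only measured step is an at least 1.5-fold higher number from compound 1 to compound 2 (0.18 log units; that floor lies within the scatter). It swaps one bromine-bearing chain end for another, so it gives no size for an exchange of this kind and only weakly bears on it. For the measured compounds named here, the only numbered reference is compound 1 at 64900 nM. A move to a lower number is therefore expected in this assay, though its size is poorly constrained and the margin must stay wide.

The expected change is an at least 5.0-fold lower number from compound 2 to compound 3 (0.69 log units; beyond the scatter). For compound 3 the estimate is 20000 nM, with an expected range from 4000 nM to 90000 nM.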

Compound 3, half-maximal inhibitory concentration: 49600 nM
For compound 3 the middle estimate is 2.5-fold (0.39 log units) below the measured one, and the stated range covers the measured number.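

In this assay, exchanging the bromine atom of compound 1 for the group of 9 heavy atoms with its six-membered non-aromatic ring gives a 1.3-fold lower number from compound 1 to compound 3 (0.12 log units; within the scatter), so at this chain end a far larger group carrying 3 hydrogen-bond acceptors leaves the reading within the scatter of the bromide. Against the longer-chain bromide, the result is an at least 2.0-fold lower number from compound 2 to compound 3 (0.30 log units; that floor lies within the scatter), and this step also lies within the scatter at its floor. Compound 2 reads > 100000 nM, which is a limit of the assay and not a number, and the step can be read only as a floor because of that limit: the limit of > 100000 nM in this assay, at which 1 of the 3 values shown sits.

The compounds shown leave open whether any group on this chain carbon can move the number beyond the scatter from compound 1, for instance a simple amine or a carboxylic acid in place of the group in compound 3. They also leave open how the same end group would read on a longer chain, which would separate the effect of chain length from that of the end group.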